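Lengthening the chain of the hydroxycarbamoyl esters

The source may hold more compounds than are shown below. What is called first, only, known or untested is meant among the compounds shown, and "the series" means these compounds.

In a functional assay on HCT-116 cells (Homo sapiens) for inhibition, read by MTT assay, with a stated time of 48 h (a higher number here means a weaker inhibitor, a lower number a stronger inhibitor), compound 1 `O=C(CCCOC(=O)c1ccc2c(c1)no[n+]2[O-])NO` gives 2060 nM and compound 2 `O=C(CCCCCCOC(=O)c1ccc2c(c1)no[n+]2[O-])NO` gives 1090 nM. Among the compounds with values here, these are the only two values so far and they lie within the scatter of each other, so compound 2 holds no firm rank. Next comes compound 3 `O=C(CCCCCCCOC(=O)c1ccc2c(c1)no[n+]2[O-])NO`, with the change (hydroxycarbamoyl)methyl in place of hydroxycarbamoyl on a saturated chain carbon, six bonds along the chain from an oxygen next to a carbonyl group. Within the data shown here, one measured step bears on this: a 1.9-fold lower number from compound 1 to compound 2 (0.28 log units; within the scatter), where 3-(hydroxycarbamoyl)propyl replaced hydroxycarbamoyl. That larger extension stayed within the scatter, so no step beyond the scatter is expected in this assay, and no direction is favoured. The estimated 1.1-fold lower number from compound 2 to compound 3 (0.04 log units; within the scatter) is correspondingly small. For compound 3 the expected value is 1000 nM, with an estimated range of 450 nM to 2200 nM.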

Compound 3, half-maximal inhibitory concentration: 2290 nM
Compound 3: middle estimate off by 2.3-fold (0.36 log units), on the low side; measured number above the stated range.
By their numbers in this assay, from the lowest: compounds 2, 1 and 3 (each within the scatter of the next, the first and the last beyond it).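

In this assay, within the data shown here, the small change of (hydroxycarbamoyl)methyl in place of hydroxycarbamoyl on a saturated chain carbon, six bonds along the chain from an oxygen next to a carbonyl group, gives a 2.1-fold higher number from compound 2 to compound 3 (0.32 log units; beyond the scatter), the first step beyond the scatter, though a modest one. The larger change, 4-(hydroxycarbamoyl)butyl in place of hydroxycarbamoyl, gives a 1.1-fold higher number from compound 1 to compound 3 (0.05 log units; within the scatter), so the numbers follow no steady course with chain length, and compound 2 stands apart only from compound 3. Nothing shown accounts for the step from compound 2 to compound 3.

Going by these compounds, whether a longer chain than that of compound 3 stays in this range remains open. Also open, on these data alone, is how a carboxylic acid or a primary amide would read in place of the hydroxycarbamoyl end of the chain.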